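The source may hold more compounds than are shown below. What is called first, only, known or untested is meant among the compounds shown, and "the series" means these compounds.

Series notes, cytotoxicity. In an ADME assay on MDBK cells (Bos taurus) for cytotoxicity, read by MTT assay, with a stated time of 96 h (a higher number here means that more compound is tolerated, a lower number that less compound is tolerated), compound 1 `CN(C)CCCNc1ccc(/N=N/c2ccccc2)cc1` gives 58000 nM. Compound 3 `c1ccc(/N=N/N2CCCC2)cc1` in this assay reaches only the limit > 100000 nM, not a number. Compound 2 `O=[N+]([O-])c1cccc(/N=N/N2CCCC2)c1` in this assay likewise sits at the limit > 100000 nM, not a number. Among the compounds with values here, two of the three values shown thus rest on (the limit of > 100000 nM in this assay, at which 2 of the 3 values shown sit), and compound 1 carries the only number. The step from compound 3 to compound 2 is nitro in place of hydrogen on an aromatic carbon; it amounts to a step that the two limits leave unreadable from compound 3 to compound 2. The difference between the core of compound 1 and that of compound 3 is not broken down here.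

Compound 4 `CN(C)CCCNc1ccc(/N=N/c2ccc([N+](=O)[O-])cc2)cc1` is not yet measured in this assay. From compound 1 it differs by nitro in place of hydrogen on an aromatic carbon. This is the same kind of change as from compound 3 to compound 2, not the same: there the nitro enters meta to a group of 7 heavy atoms, here para to a large group. Since the measured step is unreadable, the expectation for this assay rests on compound 1 at 58000 nM and an expected step of about a 1.2-fold lower number from compound 1 to compound 4 (0.06 log units; within the scatter). Compound 4 is estimated at 50000 nM, between 20000 nM and 120000 nM.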

Compound 4, half-maximal cytotoxic concentration: > 100000 nM
Compound 4 was reported as a limit (the forecaster's own chance of this, stated with the estimate: 25%); middle value at least 2.0-fold (0.30 log units) from the limit.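

In this assay, nitro in place of hydrogen on an aromatic carbon of the core of compound 1 gives an at least 1.7-fold higher number from compound 1 to compound 4 (0.23 log units; that floor lies within the scatter), so the change shows no step beyond the scatter on this core. From the compounds shown here alone, compound 4 stands at a limit, not a number, so the real size of this step stays unknown and only its floor can be stated. The same change on the other core cannot be read, so the two steps cannot be set against each other, and the data neither show that the change carries from one core to the other nor show that it does not; all that is shared is the limit: the limit of > 100000 nM in this assay, at which 3 of the 4 values shown sit.

Going by these compounds, whether a nitrile or a carboxylic acid in place of the same hydrogen on the core of compound 1 would give a number rather than a limit stays open. Also open, on these data alone, is how a longer chain in place of the chain of compound 1 would read in this assay.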